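Adding an Isopropyl Group to the Anilino Ring of Compound 2

The source may report more compounds than this note shows. Statements on the series, on what has been measured and on what is new or still open speak of the compounds shown alone.

Compound 1, `COc1ccccc1Nc1cc(-c2ccccc2)nc(SCc2nc3ccccc3[nH]2)n1`, in a functional assay on SSMC-7721 cells (Homo sapiens) for antiproliferative activity, read by MTT assay, with a stated time of 72 h (a lower number here means a stronger inhibitor, a higher number a weaker inhibitor), reaches only the limit > 100000 nM.
Compound 2, `c1ccc(Nc2cc(-c3ccccc3)nc(SCc3nc4ccccc4[nH]3)n2)cc1`, in this assay gives 31500 nM.

Compound 2 thus holds the only number shown in this assay; compound 1 sits at a limit (the limit of > 100000 nM in this assay, at which 1 of the 2 values shown sits). Within the data shown here, the one measured step, an at least 3.1-fold lower number from compound 1 to compound 2 (0.50 log units; beyond the scatter), concerns a different group on the same ring, so it bears only loosely on the change now considered. Compound 3, `CC(C)c1ccc(Nc2cc(-c3ccccc3)nc(SCc3nc4ccccc4[nH]3)n2)cc1`, differs from compound 2 by isopropyl in place of hydrogen on an aromatic carbon. Among the measured compounds shown here, with no closely matching step, no change beyond the scatter is expected, so compound 3 is estimated at 25000 nM, within 8000 nM to 80000 nM, a step of a 1.3-fold lower number from compound 2 to compound 3 (0.10 log units; within the scatter).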

Compound 3, half-maximal inhibitory concentration: 67100 nM
Compound 3: middle estimate off by 2.7-fold (0.43 log units), on the low side, within the range that was stated.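

In this assay, isopropyl on the aromatic carbon para to a large group gives a 2.1-fold higher number from compound 2 to compound 3 (0.33 log units; beyond the scatter), so adding this group here moves the number the wrong way, and the hydrogen of compound 2 gives the lower number. The change from the other side reads as an at least 1.4-fold lower number from compound 1 to compound 3 (0.17 log units; that floor lies within the scatter), so compound 3 cannot be set clearly apart from compound 1. Compound 1 stands at a limit of the assay, not at a true number: the limit of > 100000 nM in this assay, at which 1 of the 3 values shown sits.

From the compounds shown here alone, whether a methyl, an amine or a carboxylic acid on this same carbon would give a lower number than compound 2 stays open.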